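Ethyl in Place of Fluoro on the Sulfanyl Aryl Ring

The source may report more compounds than this note shows. Statements on the series, on what has been measured and on what is new or still open speak of the compounds shown alone.

Measured compounds:
compound 1 `Nc1ccccc1NC(=O)/C=C/c1ccc(CSc2ccc(F)cc2)cc1`: 59.1%
compound 2 `Nc1ccccc1NC(=O)c1ccc(CSc2ccc(Cl)cc2)cc1`: 50.4%
compound 3 `Nc1ccccc1NC(=O)c1ccc(CSCCc2ccccc2)cc1`: 84.1%

In a functional assay on A549 cells (Homo sapiens) for inhibition, read by CCK-8 assay, with a stated time of 72 h, tested at 8 uM (a lower number here means less inhibition of growth, a higher number more inhibition of growth at the concentration tested), compound 1 gives 59.1%, the second highest of the three numbers. Compound 2 gives 50.4%, which lies within the scatter of compound 1. Compound 3 gives 84.1%, beyond the scatter of compound 1.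

Compound 4 `CCc1ccc(SCc2ccc(/C=C/C(=O)Nc3ccccc3N)cc2)cc1` differs from compound 1 by ethyl in place of fluoro on an aromatic carbon. Among the compounds with values here, the only step among the measured pairs, a number 33.7 percentage points higher from compound 2 to compound 3 (beyond the scatter), concerns what hangs on the sulfur and so does not bear on a substituent of the aryl ring. Within the data shown here, no measured pair shows this change, so the step is expected to be no larger than the scatter, a number 0.9 percentage points higher from compound 1 to compound 4 (within the scatter). Compound 4 is therefore estimated at 60%, with a range from 42% to 78%.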

Compound 4, percent growth inhibition at one concentration: 68.6%
Compound 4: the middle estimate sits 8.6 percentage points below what was measured, and the stated range covers the measured number.
By their numbers in this assay, from the lowest: compounds 2, 1 and 4 (each within the scatter of the next, the first and the last beyond it); then compound 3.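

In this assay, ethyl in place of fluoro on this aromatic carbon, para to a large group, gives a number 9.5 percentage points higher from compound 1 to compound 4 (within the scatter), so this position accepts the larger of the two groups without a step beyond the scatter. Within the data shown here, this is the first measured change on the sulfanyl aryl ring itself, and it concerns only 4-fluorophenyl and 4-ethylphenyl. No measurement offered here explains the step.

Going by these compounds, whether an amine, a carboxylic acid or a longer chain at this position would keep the number stays open. Also open, on these data alone, is whether phenethyl on the sulfur would give a large step on the core of compound 1.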